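Swapping methoxy for chloro on the cinnamate ring

This account rests on a few compounds, and the source may have more. Where it says the series, first, only, none or still open, it means among the compounds named here.

Measured so far:
compound 1, `COc1cc(OC)c(OC)cc1/C=C/COC(=O)/C=C/c1ccccc1C(F)(F)F`: 50%
compound 2, `COc1ccc(/C=C/C(=O)OC/C=C/c2cc(OC)c(OC)cc2OC)cc1`: 0%

Two compounds share the same core and differ only in the aromatic ring attached to the unsaturated ester. In a functional assay on the whole organism (strain Kunming) with Mus musculus as the target, with a stated time of 0.5 h, at a dose of 300 mg/kg by the intraperitoneal route (a lower number here means a stronger effect, a higher number a weaker effect of the compound at the dose given), compound 1 gives 50%, and in this assay compound 2 gives 0%. Within the data shown here, compound 2 stands at the lower of the two numbers, which on this read-out means the stronger effect; the only step measured, a number 50 percentage points lower from compound 1 to compound 2 (beyond the scatter), is large and lies beyond the scatter.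

Compound 3, `COc1cc(OC)c(OC)cc1/C=C/COC(=O)/C=C/c1ccc(Cl)cc1`, has not been measured. It differs from compound 2 as follows: chloro in place of methoxy on an aromatic carbon. Cut one bond further out, this reads 4-methoxyphenyl to 4-chlorophenyl.

Among the measured compounds shown here, no measured step covers a chloro-for-methoxy exchange. For the measured compounds named here, the one step measured shows only that changing the group on this ring can move the read-out a long way. The expectation for compound 3 is therefore uncertain, with a step of a number 20 percentage points higher from compound 2 to compound 3 (beyond the scatter) estimated, in the direction of a weaker effect. Compound 3 is expected to give about 20%, within a range from 0% to 50%.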

Compound 3, a percentage reported as activity, at one dose (the size of the read-out at that dose, not a potency): 25%
Compound 3: the middle estimate sits 5 percentage points below what was measured, within the range that was stated.
By their numbers in this assay, from the lowest: compound 2; then compound 3; then compound 1.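

In this assay, the exchange at this aromatic carbon, para to a large group, gives a number 25 percentage points higher from compound 2 to compound 3 (beyond the scatter), so chloro and methoxy are not interchangeable here, and methoxy goes with the stronger effect at the dose given. The other comparison gives a number 25 percentage points lower from compound 1 to compound 3 (beyond the scatter), which places the 4-chlorophenyl compound between the other two, with each of these steps beyond the usual scatter; the ring on the unsaturated ester therefore gives three separate levels of effect, not simply a high and a low one. The data offer no measured property that would account for this order of the three groups.

The compounds shown leave open how other groups on this same aromatic carbon, such as a hydroxyl or an amine, would compare with methoxy and chloro. The step between 2-(trifluoromethyl)phenyl and 4-chlorophenyl also changes both the substituent and where it sits on the ring, so the effect of the group itself cannot be separated from the effect of its place.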